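A closer heteroaryl amine for the shared core

The source may hold more compounds than are shown below. What is called first, only, known or untested is meant among the compounds shown, and "the series" means these compounds.

a functional assay on DU-145 cells (Homo sapiens) for inhibition, read by trypan blue exclusion, with a stated time of 72 h (a higher number here means a weaker inhibitor, a lower number a stronger inhibitor), is the measure used throughout. Compound 1 `Cn1c(=O)c(S(=O)(=O)Cc2ccc(F)cc2)cc2cnc(Nc3ccc4[nH]ccc4c3)nc21` gives 30000 nM, compound 2 `Cn1c(=O)c(S(=O)(=O)c2ccc(Cl)cc2)cc2cnc(Nc3ccc4[nH]ccc4c3)nc21` gives 250 nM, and compound 3 `Cc1ccc(S(=O)(=O)c2cc3cnc(Nc4cccc5cccnc45)nc3n(C)c2=O)cc1` gives 10000 nM. Among these three numbers compound 3 stands second highest: compound 1 lies nearest with a higher number, and compound 2 lies furthest with a lower number, both gaps beyond the scatter. For the measured compounds named here, the one step within a single change, a 120-fold lower number from compound 1 to compound 2 (2.08 log units; beyond the scatter), concerns the group on the sulfonyl sulfur and not the amine, so it does not bear on the change considered here.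

Compound 4 `Cc1ccc(S(=O)(=O)c2cc3cnc(Nc4cnc5[nH]ccc5c4)nc3n(C)c2=O)cc1` differs from compound 3 only at the amine nitrogen: a group of 9 heavy atoms (7 carbon, 2 nitrogen; one five-membered aromatic ring with 1 hetero atom, one six-membered aromatic ring with 1 hetero atom) in place of a group of 10 heavy atoms (9 carbon, 1 nitrogen; one six-membered aromatic ring of carbon only, one six-membered aromatic ring with 1 hetero atom), on a nitrogen on an aromatic ring. Going by the values given here, no measured pair isolates this change. Compound 2 carries a bicyclic group with a ring hydrogen-bond donor on that nitrogen, as compound 4 does, yet it also differs from compound 3 at the sulfonyl aryl, so the two values of compound 2 and compound 3 cannot be split between the two sites. Among the compounds with values here, with that caveat, compound 4 is expected to give 1500 nM, within 300 nM to 8000 nM, meaning an expected step of a 6.7-fold lower number from compound 3 to compound 4 (0.82 log units; beyond the scatter) toward a lower number, held loosely since the data offer no direct precedent.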

Compound 4, half-maximal inhibitory concentration: 25000 nM
For compound 4 the middle estimate is 17-fold (1.22 log units) below the measured one, outside the stated range (above it).
By their numbers in this assay, from the lowest: compound 2; then compound 3; then compounds 4 and 1 (each within the scatter of the next).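

For the compounds shown here, this is the first pair in the set that changes only the group on the amine nitrogen while the rest of the molecule stays fixed, and in this assay it gives a 2.5-fold higher number from compound 3 to compound 4 (0.40 log units; beyond the scatter). The change is modest but beyond the scatter, so quinolin-8-yl, with no hydrogen-bond donor, gives the stronger inhibitor of this pair, and the entering bicyclic group, with its hydrogen-bond donor, does not by itself produce a low number on this sulfonyl-bearing compound. The data shown offer no independent measurement that explains this difference between the two groups.

Compound 2 differs from compound 3 and compound 4 at both the sulfonyl aryl and the amine group, so how much of its low number comes from each site remains unresolved, and the amine group of compound 2 would need to be read with the sulfonyl aryl of compound 3 to separate them. Going by these compounds, it also remains open how a simpler group on that nitrogen, such as a plain phenyl or a 3-pyridyl ring, would compare with these two bicyclic groups.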